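Bromo for trifluoromethoxy in a series held at a limit

A few compounds are considered here, and "the series" means these few. Any claim that something is new, unique, unknown or untested is made for them only; others in the source may bear on it.

Of the compounds shown here, three with a shared core have been read in an ADME assay on HepG2 cells (Homo sapiens) for cytotoxicity, read by CellTiter-Glo and resazurin assay, with a stated time of 72 h; on this read-out lower numbers stand for an effect already at smaller amounts and higher numbers for an effect only at larger amounts of compound: compound 1 (`CCOC(=O)CCCCCOc1cccc(CN(C(=O)c2ccc(-c3ccc4ccccc4c3)cc2)C(C)C)c1`), compound 2 (`CCOC(=O)CCCCCOc1cccc(CN(C(=O)c2ccc(-c3ccncc3)cc2)C(C)C)c1`) and compound 3 (`CCOC(=O)CCCCCOc1cccc(CN(C(=O)c2ccc(-c3cccc(OC(F)(F)F)c3)cc2)C(C)C)c1`). Compound 1 gives > 26000 nM, which is a limit and not a number. Compound 2 gives > 26000 nM, again a limit. Compound 3 gives > 26000 nM, likewise only a limit. Compound 3 therefore has no number of its own, and its place is the limit of > 26000 nM in this assay, at which 3 of the 3 values shown sit.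

Compound 4 (`CCOC(=O)CCCCCOc1cccc(CN(C(=O)c2ccc(-c3cccc(Br)c3)cc2)C(C)C)c1`) carries bromo in place of trifluoromethoxy on an aromatic carbon, meta to a large group: bromo in place of trifluoromethoxy on an aromatic carbon.

Among the compounds with values here, three measured steps bear on this change: a step that the two limits leave unreadable from compound 1 to compound 3, a step that the two limits leave unreadable from compound 2 to compound 3 and a step that the two limits leave unreadable from compound 1 to compound 2. None of them has a readable size, and naphthalen-2-yl, pyridin-4-yl and 3-(trifluoromethoxy)phenyl all leave the read-out at the same limit. These steps give no direction for the change at this position. The step expected in this assay is a step that the limit leaves unreadable from compound 3 to compound 4, which means none beyond the scatter. For compound 4 the estimate is 30000 nM, with an expected range from 15000 nM to 50000 nM, and a report of only a limit is the likeliest outcome.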

Compound 4, half-maximal effective concentration: > 26000 nM
Compound 4: only a limit was reported (the forecaster's own chance of this, stated with the estimate: 85%); the middle value is on the limit's open side.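

In this assay, within the data shown here, no step to compound 4 from compound 1, compound 2 or compound 3 can be read, and all four compounds stand at one limit: the limit of > 26000 nM in this assay, at which 4 of the 4 values shown sit. The compounds shown leave open whether any of them gives an actual number in this assay and whether 3-bromophenyl and 3-(trifluoromethoxy)phenyl differ there at all.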